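The compounds below may be only part of what the source reports. "The series", "measured", "known", "first", "only" and "open" are said of these compounds alone.

Series notes. The shared core is carried by compound 1 `CCOc1nc(N)nc2c1ncn2/C=C1/CC1(CO)CO`, compound 2 `CCCCCCCCOc1nc(N)nc2c1ncn2/C=C1/CC1(CO)CO` and compound 3 `Nc1nc(OCc2ccccc2)c2ncn(/C=C3/CC3(CO)CO)c2n1`, which differ only in the group attached to the oxygen on the aromatic ring. In an ADME assay on BCBL1 cells (Homo sapiens) for cytotoxicity, with a stated time of 7 days (a higher number here means that more compound is tolerated, a lower number that less compound is tolerated), compound 1 gives > 20000 nM, which is a limit of the assay and not a number. In this assay compound 2 gives > 20000 nM, again a limit. Compound 3 gives > 20000 nM in this assay, also a limit. Compound 1 thus stands at the limit with no number of its own, and the two further values are limits as well. The three steps among the measured compounds, a step that the two limits leave unreadable from compound 1 to compound 2, a step that the two limits leave unreadable from compound 1 to compound 3 and a step that the two limits leave unreadable from compound 2 to compound 3, cannot be read for size because of the limit of > 20000 nM in this assay, at which 3 of the 3 values shown sit.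

Compound 4 `CC(C)Sc1nc(N)nc2c1ncn2/C=C1/CC1(CO)CO` is not yet measured in this assay. It differs from compound 1 in isopropylsulfanyl in place of ethoxy on an aromatic carbon. Going by the values given here, none of the measured steps involves a sulfur; all three vary only the chain on the oxygen, and each is unreadable. Among the compounds with values here, their only bearing is that every variation at this position so far has left the read-out at the limit. No step beyond the scatter is therefore expected in either direction. For compound 4 the estimated step is a step that the limit leaves unreadable from compound 1 to compound 4. For compound 4 the expected value in this assay is 25000 nM, with a range from 10000 nM to 80000 nM, and most likely the assay will again report only the limit.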

Compound 4, half-maximal cytotoxic concentration: > 20000 nM
Compound 4: a limit, no number (the forecaster's own chance of this, stated with the estimate: 85%); the middle value does not contradict the limit.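

In this assay compound 4 gives > 20000 nM as a limit of the assay and not a number. No new step can be read: those linking compound 4 to compound 1, compound 2 and compound 3 have no readable size because all four compounds share one limit: (the limit of > 20000 nM in this assay, at which 4 of the 4 values shown sit). The compounds shown leave open at what concentration any of them becomes cytotoxic to these cells.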